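Sulfonyl tetrahydronaphthalene series: urea in place of hydroxyethylamine

This account rests on a few compounds, and the source may have more. Where it says the series, first, only, none or still open, it means among the compounds named here.

Measured so far:
compound 1, `O=S(=O)(c1cccc(F)c1)c1ccc2c(c1)CCC[C@H]2CNCCO`, 0.126 nM
compound 2, `O=S(=O)(c1cccc(F)c1)c1cc(F)c2c(c1)CCC[C@H]2CNCCO`, 0.159 nM

Of the two numbers in an assay on isolated protein for displacement of a labelled ligand from 5-hydroxytryptamine receptor 6 (Homo sapiens) (on this read-out higher numbers stand for weaker inhibition and lower numbers for stronger inhibition), compound 2 gives the higher, but the step of a 1.3-fold higher number from compound 1 to compound 2 (0.10 log units; within the scatter) lies within the scatter, so the two stand together. Compound 3, `NC(=O)NC[C@@H]1CCCc2cc(S(=O)(=O)c3cccc(F)c3)cc(F)c21`, carries carbamoyl in place of 2-hydroxyethyl on an amine nitrogen. For the measured compounds named here, no measured step touches the amine side of the molecule; the single measured step concerns a fluoro substituent and gives no bearing here. The expectation rests on compound 2 alone, with wide uncertainty for a change of this kind. For compound 3 in this assay the estimate is 0.5 nM, range 0.1 nM to 3 nM, meaning an expected step of a 3.1-fold higher number from compound 2 to compound 3 (0.50 log units; beyond the scatter).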

Compound 3, inhibition constant: 0.2 nM
The estimate for compound 3 lay 2.5-fold (0.40 log units) above the measured number, within the range that was stated.
By their numbers in this assay, from the lowest: compounds 1, 2 and 3 (each within the scatter of the next).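

In this assay, carbamoyl in place of 2-hydroxyethyl on an amine nitrogen gives a 1.3-fold higher number from compound 2 to compound 3 (0.10 log units; within the scatter) and so the two compounds stand together. For the compounds shown here, this is the first measured change on the amine side, and it shows that, at least on this fluoro-bearing core, the ureido form holds the number that the (2-hydroxyethyl)amino form gives. Nothing available explains this result.

As far as these compounds go, an acetyl or methylsulfonyl group in place of carbamoyl on that nitrogen, or a longer chain there, remains open. So does the ureido group on the core of compound 1.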